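Iodo for Ethynyl on a Methylamino Core

The compounds below may be only part of what the source reports. "The series", "measured", "known", "first", "only" and "open" are said of these compounds alone.

Compound 1 `Cc1ncnc2c1c(I)cn2[C@@H]1O[C@H](CO)[C@@H](O)[C@H]1O` gives 4720 nM in a functional assay on HCT-116 cells (Homo sapiens), read by MTT assay, with a stated time of 72 h; a higher number here means a weaker inhibitor, a lower number a stronger inhibitor. Compound 2 `C#Cc1cn([C@@H]2O[C@H](CO)[C@@H](O)[C@H]2O)c2ncnc(C)c12` gives only a limit in this assay, > 20000 nM. Compound 3 `C#Cc1cn([C@@H]2O[C@H](CO)[C@@H](O)[C@H]2O)c2ncnc(NC)c12` also gives only a limit in this assay, > 20000 nM.

Compound 4 `CNc1ncnc2c1c(I)cn2[C@@H]1O[C@H](CO)[C@@H](O)[C@H]1O` has not been measured in this assay. It differs from compound 3 by iodo in place of ethynyl on an aromatic carbon. The same change, word for word in its place, separates compound 2 from compound 1: iodo in place of ethynyl on an aromatic carbon, and there it produced an at least 4.2-fold lower number from compound 2 to compound 1 (0.62 log units; beyond the scatter). The two cores differ by methylamino in place of methyl on an aromatic carbon; the step this made, a step that the two limits leave unreadable from compound 2 to compound 3, cannot be sized because the limit of > 20000 nM in this assay, at which 2 of the 3 values shown sit, hides both ends.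

The reading for compound 4 therefore rests on a single comparison. Compound 4 is expected to be stronger than compound 3 by about an at least 3.3-fold lower number from compound 3 to compound 4 (0.52 log units; beyond the scatter), a step of the size seen from compound 2 to compound 1, though the limit for compound 3 leaves its true starting point open. Compound 4 is estimated to reach 6000 nM, between 1500 nM and 25000 nM.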

Compound 4, half-maximal inhibitory concentration: > 100000 nM
Compound 4 ended at the assay's limit; the forecaster's own chance of this, stated with the estimate: 35%; at least 16-fold (1.22 log units) between middle value and limit.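

With iodo on the aromatic carbon held fixed, methylamino in place of methyl gave an at least 21-fold higher number from compound 1 to compound 4 (1.32 log units; beyond the scatter), so on this pair the exchange of those two groups came with a large loss of activity. In this assay compound 4 gives > 100000 nM, which is a limit of the assay, so the steps with a limit at both ends cannot be read: the limit of > 100000 nM in this assay, at which 1 of the 4 values shown sits. Whether iodo in place of ethynyl, which gave an at least 4.2-fold lower number from compound 2 to compound 1 (0.62 log units; beyond the scatter), carries over to the core of compound 3 is therefore neither shown nor ruled out, although no gain can be seen there.

The compounds shown leave open how another group on that aromatic carbon, such as bromo, chloro or a nitrile, would behave on either core. They also leave open whether a different group in place of methyl, such as an unsubstituted amino group, ethylamino or dimethylamino, would follow methylamino or stay closer to compound 1.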